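This account rests on a few compounds, and the source may have more. Where it says the series, first, only, none or still open, it means among the compounds named here.

Measured compounds in this set:

compound 1 `C#CCCOC(=O)c1ccc(C(CC)(CC)c2ccc(C#CC(O)(CC)CC)c(C)c2)n1CC`, > 50000 nM
compound 2 `CCn1c(C(=O)NCCC(=O)O)ccc1C(CC)(CC)c1ccc(C#CC(O)(CC)CC)c(C)c1`, > 50000 nM

In a functional assay on MCF7 cells (Homo sapiens) for antiproliferative activity, read by MTT assay, with a stated time of 72 h (a lower number here means a stronger inhibitor, a higher number a weaker inhibitor), compound 1 gives > 50000 nM, which is a limit of the assay and not a number. Compound 2 gives > 50000 nM, likewise a limit. Both values sit at the limit of > 50000 nM in this assay, at which 2 of the 2 values shown sit. The step that the two limits leave unreadable from compound 1 to compound 2 is therefore unreadable in size and direction, and the pair yields no calibration for changes on the carbonyl carbon.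

Compound 3 `CCn1c(C(=O)NCCCO)ccc1C(CC)(CC)c1ccc(C#CC(O)(CC)CC)c(C)c1` differs from compound 1 by (3-hydroxypropyl)amino in place of (but-3-yn-1-yl)oxy on a carbonyl carbon. For the measured compounds named here, the one measured step concerns the same position and a related chain, (2-carboxyethyl)amino, and it is the unreadable step above; no other step bears on the change. With compound 1 standing at the limit and compound 2 also at the limit, no movement beyond the scatter is expected, and a limit is again the most likely readout. Compound 3 is estimated at 50000 nM, with a range from 20000 nM to 120000 nM. The step of a number no higher from compound 1 to compound 3 (the limit leaves the size open) is expected to be none beyond the scatter.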

Compound 3, half-maximal inhibitory concentration: 5950 nM
The estimate for compound 3 lay 8.4-fold (0.92 log units) above the measured number, outside the stated range (below it).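

In this assay, for the compounds shown here, the carbonyl carbon is the first place where a change moves the read-out off the limit: (3-hydroxypropyl)amino in place of (but-3-yn-1-yl)oxy gives an at least 8.4-fold lower number from compound 1 to compound 3 (0.92 log units; beyond the scatter). Further out on the saturated chain, two bonds along from the amide-type nitrogen, hydroxymethyl in place of carboxy gives an at least 8.4-fold lower number from compound 2 to compound 3 (0.92 log units; beyond the scatter), so among the compounds shown, an amide-type nitrogen on this carbonyl carbon does not by itself go with the lower number, and the chain end also counts. The step between the two compounds at the limit cannot be read, and the sizes of the two readable steps are minimum sizes only: the limit of > 50000 nM in this assay, at which 2 of the 3 values shown sit.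

Still open, going by these compounds, is whether the hydroxyl of the (3-hydroxypropyl)amino group is required, which a plain propyl chain on the amide nitrogen would test against compound 3. Also open, on these data alone, is how far the chain end tolerates change, for which a longer hydroxyalkyl chain or a terminal amine would be the next points of comparison.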